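This account rests on a few compounds, and the source may have more. Where it says the series, first, only, none or still open, it means among the compounds named here.

Measured compounds:
compound 1, `CC(=O)Nc1c(C#N)c(-c2ccccc2)cn1-c1ccc(S(=O)(=O)Nc2ccccn2)cc1`, 30.3% in a functional assay on HepG2 cells (Homo sapiens) for antiproliferative activity, read by sulforhodamine B assay, with a stated time of 48 h, tested at 5 uM; a lower number here means a weaker effect, a higher number a stronger effect of the compound at the concentration tested
compound 2, `N#Cc1c(-c2ccccc2)cn(-c2ccc(S(=O)(=O)Nc3nccs3)cc2)c1NC(=O)CCC(=O)O`, 25%

Compound 2 stands at the lower of the two numbers in this assay, and its nearest neighbour is compound 1, whose value lies within the scatter of repeated measurements; the two compounds differ in more than one place, so their numbers show only that both sit at a similar, modest level of activity.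

Compound 3, `N#Cc1c(-c2ccccc2)cn(-c2ccc(S(=O)(=O)Nc3ccccn3)cc2)c1NC(=O)CCC(=O)O`, is not yet measured. It differs from compound 2 in one place: pyridin-2-yl in place of 1,3-thiazol-2-yl on a sulfonamide nitrogen. Compound 1 carries the same pyridin-2-yl group and shows no separation from compound 2 beyond the scatter, so no clear direction is suggested. For compound 3 the expected step of a number 3 percentage points higher from compound 2 to compound 3 (within the scatter) is estimated to be none beyond the scatter. Compound 3 is therefore expected to give about 28%, estimated to lie between 15% and 42%.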

Compound 3, a percentage reported as activity, at one concentration (the size of the read-out at that concentration, not a potency): 15.1%
The estimate for compound 3 lay 12.9 percentage points above the measured number; the range from low to high includes it.
By their numbers in this assay, from the lowest: compounds 3, 2 and 1 (each within the scatter of the next, the first and the last beyond it).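

In this assay, pyridin-2-yl in place of 1,3-thiazol-2-yl on a sulfonamide nitrogen gives a number 9.9 percentage points lower from compound 2 to compound 3 (within the scatter), so this first direct comparison at that position does not separate the two rings. Carboxymethyl in place of hydrogen on a saturated chain carbon bound to a carbonyl carbon gives a number 15.2 percentage points lower from compound 1 to compound 3 (beyond the scatter), the only step here that clears the scatter, although its size is modest. Nothing available here gives a reason for either step.

The compounds shown leave open whether the carboxymethyl change would give a similar step with 1,3-thiazol-2-yl on the sulfonamide nitrogen. They also leave open how an amine or a longer chain in place of carboxymethyl, or pyrimidin-2-yl on the sulfonamide nitrogen, would read in this assay.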